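Extending the Aromatic Substituent of a Benzimidazolyl Pyrazolone

A few compounds are considered here, and "the series" means these few. Any claim that something is new, unique, unknown or untested is made for them only; others in the source may bear on it.

Measured compounds:
Compound 1, `Cc1[nH]n(-c2nc3cc(Cl)ccc3[nH]2)c(=O)c1Cc1ccccc1`: "not determined" (no result reported)
Compound 2, `Cc1[nH]n(-c2nc3cc(C(F)(F)F)ccc3[nH]2)c(=O)c1Cc1ccccc1`: 84%

Within the data shown here, in a functional assay on DU-145 cells (Homo sapiens) for antiproliferative activity, read by WST assay, with a stated time of 48 h, tested at 10 uM (a higher number here means a stronger effect of the compound at the concentration tested, a lower number a weaker effect), compound 2 gives 84%, which is the only number available, since compound 1 carries no result in this assay. Compound 2 therefore stands alone as the single point of reference. Compound 3, `Cc1[nH]n(-c2nc3cc(-c4ccc(Cl)cc4)ccc3[nH]2)c(=O)c1Cc1ccccc1`, has not been measured. It differs from compound 2 as follows: 4-chlorophenyl in place of trifluoromethyl on an aromatic carbon. Among the measured compounds shown here, no step between measured compounds is available to say how the shared core responds to a change of this kind, so the expectation rests on compound 2 alone. A change from a small group to a larger aromatic one at this position could move the read-out in either direction; the step from compound 2 to compound 3 is expected to be a modest decrease, a number 9 percentage points lower from compound 2 to compound 3 (within the scatter), though it may well stay within scatter. Compound 3 is estimated at 75%, with a likely range of 40% to 95%.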

Compound 3, a percentage reported as inhibition, at one concentration (the size of the read-out at that concentration, not a potency): 63%
Compound 3: the middle estimate sits 12 percentage points above what was measured; measured number inside the range.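

In this assay, among these compounds, putting 4-chlorophenyl in place of trifluoromethyl on this aromatic carbon gives a number 21 percentage points lower from compound 2 to compound 3 (beyond the scatter), the only step that can be read at this position so far. The change therefore has a real cost in this read-out, yet it does not abolish the effect: compound 3 still gives 63%, despite the larger group with its six-membered aromatic ring. No measurement offered here accounts for the drop.

The compounds shown do not separate the contribution of the ring from that of its chlorine, so the effect of an unsubstituted phenyl at this carbon remains open. Also open, from the compounds shown here alone, is how the shared core would respond to a smaller or differently built group here, such as a methoxy group, an amine or a carboxylic acid.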